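This account rests on a few compounds, and the source may have more. Where it says the series, first, only, none or still open, it means among the compounds named here.

Measured so far:
- compound 1 `CCCN(CCC)/C(C)=N/C1=Nc2ccccc2CS1`: 1 uM
- compound 2 `NC1=Nc2ccc(OC(F)(F)F)cc2CS1`: 0.001 uM

Compound 1 holds the highest of the two numbers in a functional assay (strain Wistar) with Rattus norvegicus as the target; on this read-out higher numbers stand for an effect only at larger amounts of compound and lower numbers for an effect already at smaller amounts. Compound 2, which differs from compound 1 in more than one place, gives the lower number, and the gap between the two lies beyond the scatter of repeated measurements. Among the compounds with values here, no single-change step between measured compounds is available in this assay.

Compound 3 `CCCN(CCC)/C(C)=N/C1=Nc2ccc(OC(F)(F)F)cc2CS1` is not yet measured. It differs from compound 1 by trifluoromethoxy in place of hydrogen on an aromatic carbon, a trifluoromethoxy in place of hydrogen on an aromatic carbon, at the same place where compound 2 carries its trifluoromethoxy. Because compound 2 gives 0.001 uM with that group present, a step toward a lower number is expected for compound 3, though the size cannot be separated from the other difference between compound 1 and compound 2. The expected step is a 10-fold lower number from compound 1 to compound 3 (1.00 log units; beyond the scatter). Compound 3 is estimated at 0.1 uM, with a range from 0.01 uM to 0.5 uM.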

Compound 3, minimum effective concentration: 0.01 uM
The estimate for compound 3 lay 10-fold (1.00 log units) above the measured number; measured number inside the range.
By their numbers in this assay, from the lowest: compound 2; then compound 3; then compound 1.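

With the rest of compound 1 held constant, trifluoromethoxy in place of hydrogen on this aromatic carbon gives a 100-fold lower number from compound 1 to compound 3 (2.00 log units; beyond the scatter) in this assay. Within the data shown here, this is the first direct reading of the position, as compound 1 and compound 2 differ in more than one place and their gap could not be assigned to either difference. The data give no explanation for the size of this step.

On these data alone, only hydrogen and trifluoromethoxy can be compared at this aromatic carbon, so it remains open whether a methoxy, a chlorine or a trifluoromethyl would give a similar step. A second open question is whether the step would keep its size on a compound with the free amine of compound 2, which needs a hydrogen-bearing partner of compound 2 for comparison.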